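Chloro to Phenyl on the Amide Aryl Ring: Expected Cytotoxicity

The source may report more compounds than this note shows. Statements on the series, on what has been measured and on what is new or still open speak of the compounds shown alone.

Compound 1 `O=C(CCc1cccc2c1B(O)OC2)Nc1ccc(Cl)cc1` and compound 2 `O=C(CCc1cccc2c1B(O)OC2)Nc1cccc(I)c1` share the same core and differ only in the aryl group carried on the amide-type nitrogen. In an ADME assay on WI-38 cells (Homo sapiens) for cytotoxicity, read by MTT assay, with a stated time of 72 h (on this read-out lower numbers stand for stronger inhibition and higher numbers for weaker inhibition), compound 1 gives > 100000 nM, which is a limit of the assay rather than a measured number. Compound 2 in this assay gives 71000 nM. Going by the values given here, the step of an at least 1.4-fold lower number from compound 1 to compound 2 (0.14 log units; that floor lies within the scatter) is the only measured comparison available, and its size rests on (the limit of > 100000 nM in this assay, at which 1 of the 2 values shown sits). Compound 3 `O=C(CCc1cccc2c1B(O)OC2)Nc1ccc(-c2ccccc2)cc1` has not yet been tested; it differs from compound 1 by phenyl in place of chloro on an aromatic carbon. Among the compounds with values here, the one measured step changed the same aromatic ring on the amide-type nitrogen, with 3-iodophenyl in place of 4-chlorophenyl, and shifted the read-out in this assay by an amount that sits within the usual scatter. Nothing among these compounds indicates that phenyl in place of chloro would move the number further than that, so the expected step is an at least 1.2-fold lower number from compound 1 to compound 3 (0.09 log units; that floor lies within the scatter), with no clear direction. Compound 3 is therefore estimated at 80000 nM, within a range from 35000 nM to 200000 nM.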

Compound 3, half-maximal inhibitory concentration: 32000 nM
Estimate against measurement, compound 3: 2.5-fold (0.40 log units) above; the whole stated range lies above it.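

Putting phenyl where compound 1 carries chloro, on an aromatic carbon para to a large group, gives an at least 3.1-fold lower number from compound 1 to compound 3 (0.49 log units; beyond the scatter) in this assay. This shows that a change at this position can move the read-out by more than the usual scatter, which the earlier step did not establish. The entering phenyl has no hydrogen-bond donors, no hydrogen-bond acceptors and no net charge, so a shift of this size here does not require any of those to be added, and the printed figure is only a floor on the true size of the step: the limit of > 100000 nM in this assay, at which 1 of the 3 values shown sits.

The compounds shown cannot tell whether the ring itself matters or simply the larger number of heavy atoms at this position, and they do not show whether the same swap would act alike on a different core. Also open, from the compounds shown here alone, is how the number in this assay would respond to an amine, a carboxylic acid or a longer alkyl chain placed at this same position on the amide aryl ring.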